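Adding an Isopropylcarbamoyl Cap to a Stable Series

The compounds below may be only part of what the source reports. "The series", "measured", "known", "first", "only" and "open" are said of these compounds alone.

Compound 3 `NCCS(=O)(=O)NC(=O)c1ccc(Nc2nc(NC3(c4ccc(Cl)cc4)CC3)nc(OCC(F)(F)F)n2)cc1` gives 100% in an ADME assay on microsomes from liver (Homo sapiens) for metabolic stability, with a stated time of 10 min; a higher number here means that more of the compound is left, a lower number that less of the compound is left. Its two neighbours sit at the same level: in this assay compound 1 `Cc1ccccc1S(=O)(=O)NC(=O)c1ccc(Nc2nc(NC3(c4ccc(Cl)cc4)CC3)nc(OCC(F)(F)F)n2)cc1` gives 100%, and compound 2 `CCS(=O)(=O)NC(=O)c1ccc(Nc2nc(NC3(c4ccc(Cl)cc4)CC3)nc(OCC(F)(F)F)n2)cc1` gives 100%. The three steps that connect them are all flat: no change at the digits printed from compound 1 to compound 2 (within the scatter), no change at the digits printed from compound 1 to compound 3 (within the scatter), and no change at the digits printed from compound 2 to compound 3 (within the scatter). Compound 3 therefore stands level with compound 1 and compound 2, and nothing in these numbers sets it apart.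

Compound 4 `CC(C)NC(=O)NCCS(=O)(=O)NC(=O)c1ccc(Nc2nc(NC3(c4ccc(Cl)cc4)CC3)nc(OCC(F)(F)F)n2)cc1` differs from compound 3 by isopropylcarbamoyl in place of hydrogen on an amine nitrogen. Going by the values given here, the step most comparable to this change is the one from compound 2 to compound 3, where the amine was introduced on the chain without any change in this assay; the steps from compound 1 to compound 2 and to compound 3, which exchange the whole group on the sulfonyl sulfur, were equally flat. On that basis no step beyond the scatter is expected, with a number 5 percentage points lower from compound 3 to compound 4 (within the scatter). Compound 4 is estimated at 95%, in a range from 80% to 100%.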

Compound 4, percent of the compound remaining in the liver assay: 100%
Compound 4: middle estimate off by 5 percentage points, on the low side, within the range that was stated.
By their numbers in the liver assay, from the lowest: compounds 1, 2, 3 and 4 (each within the scatter of the next).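

In the liver assay the amine nitrogen of the 2-aminoethyl chain takes the isopropylcarbamoyl group with no visible consequence, as the series shows no change at the digits printed from compound 3 to compound 4 (within the scatter), no change at the digits printed from compound 2 to compound 4 (within the scatter) and no change at the digits printed from compound 1 to compound 4 (within the scatter). A second read-out tells the two compounds apart, since in a physicochemical assay for permeability, using PAMPA, at pH 7.4 (on this read-out lower numbers stand for lower permeability and higher numbers for higher permeability), compound 3 gives 153 nm/s and compound 4 gives 45 nm/s. The change that leaves the liver read-out flat therefore does not leave apparent permeability flat: the measured apparent permeability of compound 3, 153 nm/s, and of compound 4, 45 nm/s, a 3.4-fold lower number (0.53 log units; beyond the scatter)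

As far as these compounds go, whether an acetyl group or a methylsulfonyl group on the same amine nitrogen would stay level in the liver assay and keep more of the number in the physicochemical assay stays open. So does whether a longer chain between the sulfonyl sulfur and this nitrogen would alter the picture.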